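Dropping the chloro group: from compound 3 to compound 4

A few compounds are considered here, and "the series" means these few. Any claim that something is new, unique, unknown or untested is made for them only; others in the source may bear on it.

In a functional assay, read by Griess assay, with a stated time of 150 min, tested at 50 ug/mL (on this read-out lower numbers stand for a weaker effect and higher numbers for a stronger effect at the one concentration tested), compound 1 `COc1ccc(C2=NN(c3ccccc3)C(c3ccc(C)cc3)C2S(=O)(=O)CC2=NCCO2)cc1` gives 59.1%. Compound 2 `O=S(=O)(CC1=NCCS1)C1C(c2ccccc2)=NOC1c1ccccc1` is reported in this assay as "not active" (no number reported), so no number stands for it. Compound 3 `O=S(=O)(CC1=NCCO1)c1n[nH]cc1-c1ccc(Cl)cc1` likewise comes out in this assay as "not active" (no number reported), which means that no single number describes where it stands, and compound 2 is the one further entry of that kind. Compound 4 `O=S(=O)(CC1=NCCO1)c1n[nH]cc1-c1ccccc1` has not yet been measured. It differs from compound 3 by hydrogen in place of chloro on an aromatic carbon: chloro leaves and hydrogen enters on an aromatic carbon of a six-membered aromatic ring of carbon only, para to a large group. Among the measured compounds shown here, no measured pair shows this step; in this assay one expects little shift, if any, beyond the scatter. Compound 4 is therefore estimated at 10%, between 0% and 30%.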

Compound 4, a percentage reported as activity, at one concentration (the size of the read-out at that concentration, not a potency): 50.6%
The estimate for compound 4 lay 40.6 percentage points below the measured number, outside the stated range (above it).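

Among the compounds shown here, compound 3 carries no number in this assay, so no step from it to compound 4 can be read. The compounds shown leave open what the change from 4-chlorophenyl to phenyl does to this read-out. Nothing available explains the result of compound 4.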